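The source may hold more compounds than are shown below. What is called first, only, known or untested is meant among the compounds shown, and "the series" means these compounds.

Measured so far:
compound 1, `Clc1ccc(-c2cn(Cc3ccccc3)c3c2CNCC3)cc1Cl`: 4470 nM
compound 2, `FC(F)(F)c1ccc(-c2cn(Cc3ccccc3)c3c2CNCC3)cc1`: 167 nM

Two compounds of this series have numbers in an assay on HEK293 cells for displacement of a labelled ligand from 5-hydroxytryptamine receptor 7 (Rattus norvegicus), with a stated time of 60 min; a higher number here means a weaker inhibitor, a lower number a stronger inhibitor. Compound 1 gives 4470 nM in this assay. Compound 2, with 167 nM in this assay, holds the lower of the two numbers; the gap to compound 1 is beyond the scatter. Within the data shown here, no pair that differs in a single place has been measured, so no counted step is known.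

Compound 3, `CC(C)(C)c1ccc(-c2cn(Cc3ccccc3)c3c2CNCC3)cc1`, is not yet measured. It differs from compound 2 by tert-butyl in place of trifluoromethyl on an aromatic carbon. Going by these compounds, with only compound 1 and compound 2 in hand, the step in this assay from this change is unknown; a small step, if any, is expected, with the number for compound 3 more likely somewhat higher than that of compound 2 than lower, but possibly within the scatter. Compound 3 is therefore expected to give about 280 nM in this assay, in a range of 70 nM to 1200 nM. This estimate means a step of a 1.7-fold higher number from compound 2 to compound 3 (0.22 log units; within the scatter).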

Compound 3, inhibition constant: 10000 nM
Estimate against measurement, compound 3: 36-fold (1.55 log units) below; measured number above the stated range.
By their numbers in this assay, from the lowest: compound 2; then compound 1; then compound 3.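

In this assay, among these compounds, tert-butyl in place of trifluoromethyl on an aromatic carbon gives a 60-fold higher number from compound 2 to compound 3 (1.78 log units; beyond the scatter), the first counted step. This position, para to a large group, is therefore far from indifferent to the group it carries, even though the two groups match in heavy-atom count, and neither has a ring, a hydrogen-bond donor or acceptor, or a net charge. Nothing available bears on the reason for a step of this size.

A single pair leaves open whether compound 2 or compound 3 is the exception at this carbon, and whether a methyl, a nitrile or a methoxy group would fall nearer compound 2 or compound 3. Also open, going by these compounds, is whether the step keeps its size when the rest of the shared core is changed.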